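This account rests on a few compounds, and the source may have more. Where it says the series, first, only, none or still open, it means among the compounds named here.

Of the compounds shown here, two have so far been measured in an assay on VSM-A10 cells for antagonist activity at Endothelin-1 receptor (Rattus norvegicus); on this read-out higher numbers stand for weaker inhibition and lower numbers for stronger inhibition. Compound 1 `CCCNc1ccc(S(=O)(=O)Nc2onc(C)c2C)cc1` carries a propyl group on a nitrogen attached to an aromatic ring, and in this assay compound 1 gives 27000 nM. Compound 2 `Cc1noc(NS(=O)(=O)c2cccc3c(N(C)C)cccc23)c1Cc1ccccc1` is built on a different pattern, and in this assay compound 2 gives 50000 nM. These two numbers lie within the usual scatter of each other, so neither compound can be called the stronger inhibitor; compound 1 simply has the lower of the two numbers, with compound 2 as its nearest neighbour.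

Compound 3 `Cc1noc(NS(=O)(=O)c2ccc(N/C(S)=N/c3ccccc3)cc2)c1C` has not yet been measured. It differs from compound 1 in one place: a group of 9 heavy atoms (7 carbon, 1 nitrogen, 1 sulfur; one six-membered aromatic ring of carbon only) in place of a group of 3 heavy atoms (3 carbon; no ring), on a nitrogen on an aromatic ring. Going by the values given here, no pair of measured compounds differs in just one place, so nothing measured shows how far a change of this kind moves the numbers in this assay. The expectation therefore rests on compound 1 alone, and the step that the estimate means is a 1.8-fold lower number from compound 1 to compound 3 (0.26 log units; within the scatter), a modest move toward stronger inhibition that could still fall inside the scatter. Compound 3 is thus expected to give 15000 nM in this assay, within a range from 3000 nM to 80000 nM.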

Compound 3, half-maximal inhibitory concentration: 4100 nM
For compound 3 the middle estimate is 3.7-fold (0.56 log units) above the measured one; the measured number falls inside the stated range.
By their numbers in this assay, from the lowest: compound 3; then compounds 1 and 2 (each within the scatter of the next).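

In this assay, going by these compounds alone, the nitrogen on an aromatic ring turns out to be a place where a change can move the number beyond the scatter, which the earlier compounds could not show. Putting a group of 9 heavy atoms, with its six-membered aromatic ring of carbon only, in place of propyl gives a 6.6-fold lower number from compound 1 to compound 3 (0.82 log units; beyond the scatter) and so moves toward stronger inhibition, though the step is only modest. The entering group differs from propyl in several ways at once, adding sulfur, nitrogen, a double bond outside aromatic rings, a hydrogen-bond donor and a hydrogen-bond acceptor, and nothing available explains why the number falls.

The compounds shown leave open which of these features carries the step, for example whether a benzyl group, which keeps an aromatic ring without the sulfur and nitrogen, would give a similar number. They also leave open whether a longer chain such as hexyl would move the number in the same direction, and whether a urea with oxygen in place of sulfur would match the entering group.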